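Catechol Replaces Dimethylphenyl on the Shared Core

The compounds below may be only part of what the source reports. "The series", "measured", "known", "first", "only" and "open" are said of these compounds alone.

Compound 1 `CCC1=C(O)c2c(oc(-c3cccc(OC)c3)cc2=O)C(CC)(CC)C1=O` gives 1.22 uM in a functional assay on KBVIN cells (Homo sapiens) for antiproliferative activity, read by sulforhodamine B assay, with a stated time of 3 days; on this read-out higher numbers stand for an effect only at larger amounts of compound and lower numbers for an effect already at smaller amounts.
Compound 2 `CCC1=C(O)c2c(oc(-c3ccccc3C)cc2=O)C(CC)(CC)C1=O` gives 2.41 uM.
Compound 3 `CCC1=C(O)c2c(oc(-c3ccc(C)cc3C)cc2=O)C(CC)(CC)C1=O` gives 8.52 uM.

Compound 3 stands highest of the three numbers; a 3.5-fold higher number from compound 2 to compound 3 (0.55 log units; beyond the scatter) and a 7.0-fold higher number from compound 1 to compound 3 (0.84 log units; beyond the scatter) both separate it from the others beyond the scatter. Compound 4 `CCC1=C(O)c2c(oc(-c3ccc(O)c(O)c3)cc2=O)C(CC)(CC)C1=O` differs from compound 3 in one place: 3,4-dihydroxyphenyl in place of 2,4-dimethylphenyl on an aromatic carbon. For the measured compounds named here, no measured step introduces hydroxyl groups, so guidance is indirect. The nearest is a 7.0-fold higher number from compound 1 to compound 3 (0.84 log units; beyond the scatter), where the 3-methoxyphenyl of compound 1 went with the lowest number, and a 3.5-fold higher number from compound 2 to compound 3 (0.55 log units; beyond the scatter), where an added methyl went with a higher one. A smaller number than compound 3 is therefore expected for compound 4, a step of a 2.8-fold lower number from compound 3 to compound 4 (0.45 log units; beyond the scatter). The estimated value for compound 4 is 3 uM, in the range 0.8 uM to 12 uM.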

Compound 4, concentration for half-maximal effect: 5.41 uM
For compound 4 the middle estimate is 1.8-fold (0.26 log units) below the measured one, within the range that was stated.
By their numbers in this assay, from the lowest: compounds 1 and 2 (each within the scatter of the next); then compounds 4 and 3 (each within the scatter of the next).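

The step with a 1.6-fold lower number from compound 3 to compound 4 (0.20 log units; within the scatter) shows that 3,4-dihydroxyphenyl, which brings hydrogen-bond donors and acceptors that 2,4-dimethylphenyl lacks, stays within the scatter of that group at this position. The steps with a 2.2-fold higher number from compound 2 to compound 4 (0.35 log units; beyond the scatter) and with a 4.4-fold higher number from compound 1 to compound 4 (0.65 log units; beyond the scatter) both lie beyond the scatter, so adding these donors and acceptors does not bring the number down to those of 2-methylphenyl or 3-methoxyphenyl.

On these data alone, whether an amine or a carboxylic acid on the phenyl ring would behave like the two hydroxyl groups stays open. Nothing available explains this result.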